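Moving the methyl around the benzyl ring

This account rests on a few compounds, and the source may have more. Where it says the series, first, only, none or still open, it means among the compounds named here.

For the measured compounds named here, compound 2 `COc1cccc(OC)c1OCCNCCOc1ccccc1OCc1cccc(C)c1` gives 8.2 in a functional assay on spleen for antagonist activity at Alpha-1B adrenergic receptor (Rattus norvegicus) (a lower number here means a less potent compound, a higher number a more potent compound, by a factor of ten per unit of this negative logarithm), the higher of the two numbers measured so far. Its nearest neighbour is compound 1 `COc1cccc(OC)c1OCCNCCOc1ccccc1OCc1ccccc1C`, which gives 7.67; the step of a number 0.53 log units higher from compound 1 to compound 2 (beyond the scatter) lies beyond the scatter. Compound 3 `COc1cccc(OC)c1OCCNCCOc1ccccc1OCc1ccc(C)cc1` has not yet been measured. The change from compound 2 to compound 3 is 4-methylphenyl in place of 3-methylphenyl on a saturated chain carbon bound to an oxygen on an aromatic ring. Going by the values given here, no measured step concerns this exact change; the only step on record, from compound 1 to compound 2, moves the methyl from the 2- to the 3-position of the same ring and is modest. With nothing to show that moving the methyl further has a comparable effect, compound 3 is expected to stay close to compound 2, with a step of a number 0.20 log units lower from compound 2 to compound 3 (within the scatter) that is expected to fall within the scatter. Compound 3 is therefore estimated at 8, between 7.4 and 8.6.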

Compound 3, negative logarithm of the antagonist equilibrium constant: 8.43
Estimate against measurement, compound 3: 0.43 log units below; low and high end bracket the measured number.
By their numbers in this assay, from the lowest: compound 1; then compounds 2 and 3 (each within the scatter of the next).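

With a number 0.23 log units higher from compound 2 to compound 3 (within the scatter), the 4-methylphenyl and 3-methylphenyl groups cannot be told apart at this place in this assay, so the methyl is not confined to one ring position among these two. The 2-methylphenyl group of compound 1 now stands apart from both, with a number 0.76 log units higher from compound 1 to compound 3 (beyond the scatter) adding to the earlier step, and compound 1 is the least potent of the three. Nothing measured here explains why the 2-methylphenyl compound differs from the other two. The compounds shown leave open whether a group other than methyl would be accepted on this ring, such as an unsubstituted phenyl, 4-ethylphenyl, 4-methoxyphenyl or 4-chlorophenyl in place of 4-methylphenyl. They also leave open whether a carboxylic acid or an amine on the ring would keep the numbers of compound 2 and compound 3.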